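The compounds below may be only part of what the source reports. "The series", "measured", "known", "first", "only" and "open" are said of these compounds alone.

Compound 3 `O=C(COc1ccc(-c2ccccc2)cc1)Cn1cnnn1` gives 43 nM in an assay on microsomes from brain for inhibition of Fatty-acid amide hydrolase 1 (Rattus norvegicus), read by fluorescence and HPLC, with a stated time of 60 min (on this read-out lower numbers stand for stronger inhibition and higher numbers for weaker inhibition), and stands second highest of the three numbers, close to compound 2 `CCCCCCCCc1ccc(OCC(=O)Cn2cnnn2)cc1` at 39 nM and far from compound 1 `CCCCCCCCc1ccc(OCC(=O)Cn2ncc3ccccc32)cc1` at 2300 nM. The move from compound 3 to compound 4 `CC(C(=O)COc1ccc(-c2ccccc2)cc1)n1cnnn1` is methyl in place of hydrogen on a saturated chain carbon bound to an aromatic nitrogen and a carbonyl carbon. Going by the values given here, no measured step touches this carbon directly: the large 59-fold lower number from compound 1 to compound 2 (1.77 log units; beyond the scatter) concerned the ring bound to it, while the small 1.1-fold higher number from compound 2 to compound 3 (0.04 log units; within the scatter) concerned the other end of the molecule. A methyl on the chain carbon is expected to give a 1.5-fold higher number from compound 3 to compound 4 (0.18 log units; within the scatter), within the scatter, perhaps with slight weakening. Compound 4 is therefore estimated at 65 nM, with a likely range from 20 nM to 220 nM.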

Compound 4, half-maximal inhibitory concentration: > 10000 nM
Compound 4 ended at the assay's limit (the forecaster's own chance of this, stated with the estimate: 3%); middle value at least 150-fold (2.18 log units) from the limit.
By their numbers in this assay, from the lowest: compounds 2 and 3 (each within the scatter of the next); then compound 1. At a limit, above all of these: compound 4.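

Compound 4 stands at a limit of the assay: the limit of > 10000 nM in this assay, at which 1 of the 4 values shown sits. The change reads as an at least 230-fold higher number from compound 3 to compound 4 (2.36 log units; beyond the scatter), so a single added methyl on this saturated chain carbon bound to an aromatic nitrogen and a carbonyl carbon is enough to take inhibition out of the measurable range. The earlier steps shown here changed only the groups attached at either end of the molecule, and none showed that this carbon itself is so sensitive to change. Going by these compounds, whether a fluorine or a hydroxyl on this carbon would fare better remains open, as does how weak compound 4 truly is.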